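A few compounds are considered here, and "the series" means these few. Any claim that something is new, unique, unknown or untested is made for them only; others in the source may bear on it.

Compound 1, `COc1cc(OC)c(C(=O)/C=C/c2ccc(C)cc2)c(OC)c1`, gives 15000 nM in a functional assay on A549 cells (Homo sapiens) for inhibition, read by MTT assay, with a stated time of 72 h; on this read-out higher numbers stand for weaker inhibition and lower numbers for stronger inhibition.
Compound 2, `COc1cc(OC)c(C(=O)/C=C/c2ccc([N+](=O)[O-])cc2)c(OC)c1`, gives 7100 nM in this assay.
Compound 3, `COc1cc(OC)c(C(=O)/C=C/c2ccc(C(F)(F)F)cc2)c(OC)c1`, gives 14200 nM in this assay.

Compound 3 holds the second highest of the three numbers in this assay: a 1.1-fold lower number from compound 1 to compound 3 (0.02 log units; within the scatter) and a 2.0-fold higher number from compound 2 to compound 3 (0.30 log units; within the scatter), both within the scatter. Compound 4, `COc1cc(OC)c(C(=O)/C=C/c2ccc(N)cc2)c(OC)c1`, carries amino in place of trifluoromethyl on an aromatic carbon. Among the compounds with values here, no measured step puts an amino group in place; the nearest are a 2.1-fold lower number from compound 1 to compound 2 (0.32 log units; beyond the scatter), a modest shift, and a 1.1-fold lower number from compound 1 to compound 3 (0.02 log units; within the scatter), no shift at all. The shared core has thus moved little across three substituents, so in this assay the step of a 1.6-fold lower number from compound 3 to compound 4 (0.20 log units; within the scatter) is expected to stay within the scatter. Compound 4 is therefore estimated at 9000 nM, within 3000 nM to 30000 nM.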

Compound 4, half-maximal inhibitory concentration: > 50000 nM
Compound 4: only a limit was reported; the forecaster's own chance of this, stated with the estimate: 10%; middle value at least 5.5-fold (0.74 log units) away from the limit.
By their numbers in this assay, from the lowest: compounds 2, 3 and 1 (each within the scatter of the next, the first and the last beyond it). At a limit, above all of these: compound 4.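

Compound 4 gives only a limit in this assay: the limit of > 50000 nM in this assay, at which 1 of the 4 values shown sits.

Amino is the first group at this position to push the number clearly upward, with an at least 3.5-fold higher number from compound 3 to compound 4 (0.54 log units; beyond the scatter), an at least 3.3-fold higher number from compound 1 to compound 4 (0.52 log units; beyond the scatter) and an at least 7.0-fold higher number from compound 2 to compound 4 (0.84 log units; beyond the scatter). The position is therefore not indifferent to its substituent, which methyl, nitro and trifluoromethyl, separated by a modest step at most, did not show.

The compounds shown leave open whether a hydroxyl group or an acetamide here would behave like amino or like those three groups. They also leave open how far the true number of compound 4 lies beyond its limit.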